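A few compounds are considered here, and "the series" means these few. Any claim that something is new, unique, unknown or untested is made for them only; others in the source may bear on it.

The measured compounds in an assay on CHO cells for displacement of a labelled ligand from 5-hydroxytryptamine receptor 1D (Homo sapiens); a higher number here means a weaker inhibitor, a lower number a stronger inhibitor:
Compound 1, `c1ccc2c(c1)CCC2NC1CCN(CCCc2c[nH]c3ccc(-n4cnnc4)cc23)CC1`, gives 8.9 nM.
Compound 2, `c1ccc(CNC2CCN(CCCc3c[nH]c4ccc(-n5cnnc5)cc34)CC2)cc1`, gives 4.6 nM.
Compound 3, `C[C@@H](NC1CCN(CCCc2c[nH]c3ccc(-n4cnnc4)cc23)CC1)c1ccccc1`, gives 0.4 nM.

Compound 3 has the lowest number of the three and is the most potent, since the steps of a 12-fold lower number from compound 2 to compound 3 (1.06 log units; beyond the scatter) and a 22-fold lower number from compound 1 to compound 3 (1.35 log units; beyond the scatter) both lie beyond the scatter. Compound 4, `CN(Cc1ccco1)C1CCN(CCCc2c[nH]c3ccc(-n4cnnc4)cc23)CC1`, has not yet been measured in this assay. It differs from compound 3 in one place: ((furan-2-yl)methyl)(methyl)amino in place of (1-phenylethyl)amino on a saturated ring carbon. Going by the values given here, two measured steps bear on this. The step of a 12-fold lower number from compound 2 to compound 3 (1.06 log units; beyond the scatter) shows that the methyl on the saturated chain carbon bound to the amine nitrogen accounts for a large part of the potency of compound 3, and compound 4 has no such methyl. The step of a 1.9-fold lower number from compound 1 to compound 2 (0.29 log units; within the scatter) shows that swapping one ring-bearing group for another on that nitrogen changed little. Nothing measured speaks to the furan ring or to the methyl on the nitrogen. The number for compound 4 is therefore expected to rise, by an estimated step of a 15-fold higher number from compound 3 to compound 4 (1.18 log units; beyond the scatter). The estimate for compound 4 is 6 nM, with a range from 1.5 nM to 25 nM.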

Compound 4, half-maximal inhibitory concentration: 9.3 nM
Estimate against measurement, compound 4: 1.6-fold (0.19 log units) below; the range from low to high includes it.
By their numbers in this assay, from the lowest: compound 3; then compounds 2, 1 and 4 (each within the scatter of the next, the first and the last beyond it).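

In this assay, putting ((furan-2-yl)methyl)(methyl)amino in place of (1-phenylethyl)amino on this saturated ring carbon gives a 23-fold higher number from compound 3 to compound 4 (1.37 log units; beyond the scatter), so the low number of compound 3 does not carry over to this new group. Measured against the other two amines, the same group gives a 2.0-fold higher number from compound 2 to compound 4 (0.31 log units; beyond the scatter) and a 1.0-fold higher number from compound 1 to compound 4 (0.02 log units; within the scatter), so the position tolerates a five-membered aromatic ring with an oxygen in place of a carbon-only ring with only a modest change or none beyond the scatter. Compound 3 therefore still stands apart from the other three.

As far as these compounds go, the furan ring and the methyl on the nitrogen entered together, so their separate contributions remain open, and a benzyl(methyl)amino or 1-(furan-2-yl)ethylamino group would be needed to pull them apart. No measurement shown gives a reason for these differences.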